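Aryl swap on the carbonyl from the series' lowest number

A few compounds are considered here, and "the series" means these few. Any claim that something is new, unique, unknown or untested is made for them only; others in the source may bear on it.

In a functional assay on C8166 cells (Homo sapiens) for cytotoxicity, read by MTT assay (a lower number here means that less compound is tolerated, a higher number that more compound is tolerated), compound 1 `Cc1cc(S(N)(=O)=O)ccc1NC(=O)COc1ccc(Cl)cc1NC(=O)c1cccc(F)c1`, with 3-fluorophenyl on a carbonyl carbon, gives 243000 nM. Compound 2 `Cc1ccc(C(=O)Nc2cc(Cl)ccc2OCC(=O)Nc2ccc(S(N)(=O)=O)cc2C)cc1C`, with 3,4-dimethylphenyl in that place, gives 84100 nM. Compound 3 `Cc1cc(C)cc(C(=O)Nc2cc(Cl)ccc2OCC(=O)Nc2ccc(S(N)(=O)=O)cc2C)c1`, with 3,5-dimethylphenyl, gives 36500 nM, the lowest of the three numbers, with compound 2 nearest and compound 1 furthest.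

Compound 4 `Cc1cc(S(N)(=O)=O)ccc1NC(=O)COc1ccc(Cl)cc1NC(=O)c1cc(Cl)ccc1Cl` carries 2,5-dichlorophenyl in place of the 3,5-dimethylphenyl of compound 3 on a carbonyl carbon (2,5-dichlorophenyl in place of 3,5-dimethylphenyl on a carbonyl carbon). Among the measured compounds shown here, three measured steps bear on this change, all at the same place, all modest and all beyond the scatter: a 2.9-fold lower number from compound 1 to compound 2 (0.46 log units; beyond the scatter), a 6.7-fold lower number from compound 1 to compound 3 (0.82 log units; beyond the scatter) and a 2.3-fold lower number from compound 2 to compound 3 (0.36 log units; beyond the scatter). No dichlorophenyl group has been measured, so the closest guide is thin. For the measured compounds named here, the only halogen-bearing group in this place belongs to compound 1, at 243000 nM, the highest number of the three. A modest move to a higher number is therefore expected in this assay, with the size of the measured steps as the guide. The expected change is a 2.2-fold higher number from compound 3 to compound 4 (0.34 log units; beyond the scatter). The estimate for compound 4 is 80000 nM, with an expected range of 25000 nM to 250000 nM.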

Compound 4, half-maximal cytotoxic concentration: 42100 nM
For compound 4 the middle estimate is 1.9-fold (0.28 log units) above the measured one; measured number inside the range.
By their numbers in this assay, from the lowest: compounds 3, 4 and 2 (each within the scatter of the next, the first and the last beyond it); then compound 1.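

In this assay the 2,5-dichlorophenyl group of compound 4 reads with the two dimethylphenyl groups and not with the 3-fluorophenyl group: the steps of a 1.2-fold higher number from compound 3 to compound 4 (0.06 log units; within the scatter) and a 2.0-fold lower number from compound 2 to compound 4 (0.30 log units; within the scatter) stand against a 5.8-fold lower number from compound 1 to compound 4 (0.76 log units; beyond the scatter) in this place. Halogen on this aryl group therefore does not by itself hold the number at the level of compound 1, since compound 4 also carries halogen and goes against any such reading. Among the four groups on this carbonyl carbon, only 3-fluorophenyl stands apart from the rest, and nothing measured here bears on why it does.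

From the compounds shown here alone, whether 3-chlorophenyl would read with compound 1 or with compound 4 remains open, as does the reading for 2,5-dimethylphenyl, which would separate the arrangement of the two groups on the ring from the atoms they contain. Also open, going by these compounds, is how an aryl group bearing an amine or a carboxylic acid, or a saturated cyclohexyl group, would read on this same carbonyl carbon.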